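Methyl on the azole carbon of the aminothiazoles

A few compounds are considered here, and "the series" means these few. Any claim that something is new, unique, unknown or untested is made for them only; others in the source may bear on it.

Measured so far:
Compound 1, `Brc1ccc(Nc2nc(-n3cnc4ccccc43)cs2)cc1`: in a functional assay on RKO cells (Homo sapiens) for cytotoxicity, read by resazurin assay, with a stated time of 72 h (a lower number here means a stronger inhibitor, a higher number a weaker inhibitor), compound 1 gives > 100000 nM, a limit of the assay and not a number.
Compound 2, `Cc1nc2ccccc2n1-c1csc(Nc2ccc(Br)cc2)n1`: in this assay compound 2 gives 90 nM.
Compound 3, `c1ccc(Nc2nc(-n3ccnc3)cs2)cc1`: in this assay compound 3 gives > 100000 nM, again a limit of the assay.

Going by the values given here, the one change measured is methyl in place of hydrogen on an aromatic carbon, and it produced an at least 1100-fold lower number from compound 1 to compound 2 (3.04 log units; beyond the scatter). On these data alone, since compound 1 sits at the limit, the true size of that step is unknown; what is known is that it is at least as large as stated. The same value is reached by the limit of > 100000 nM in this assay, at which 2 of the 3 values shown sit, so two of the three measured compounds are without a number.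

Compound 4, `Cc1nccn1-c1csc(Nc2ccccc2)n1`, is not yet measured. It differs from compound 3 by methyl in place of hydrogen on an aromatic carbon, the same kind of change as that from compound 1 to compound 2. The places are not identical: in compound 1 the five-membered ring is part of a fused or bridged system of two rings, in compound 3 it is not. The difference between the core of compound 3 and the core of compound 1 is not broken down here.

From compound 3 to compound 4 a large step is expected, an at least 66-fold lower number from compound 3 to compound 4 (1.82 log units; beyond the scatter), resting on the step of an at least 1100-fold lower number from compound 1 to compound 2 (3.04 log units; beyond the scatter) but taken as smaller. The core of compound 3 differs from that of compound 1 in an uncounted way, and the starting point, compound 3, is only a limit. Compound 4 is therefore estimated at 1500 nM in this assay, with an expected range from 150 nM to 40000 nM.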

Compound 4, half-maximal inhibitory concentration: 32500 nM
Estimate against measurement, compound 4: 22-fold (1.34 log units) below; the range from low to high includes it.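

Methyl in place of hydrogen on an aromatic carbon, here 1H-imidazol-1-yl to 2-methyl-1H-imidazol-1-yl, again goes with a lower number in this assay on the second core, with an at least 3.0-fold lower number from compound 3 to compound 4 (0.48 log units; beyond the scatter). The direction of the change therefore holds on both cores shown, but this is a single further case, and its printed size is only a lower bound for the step on this core, so neither a common size nor a larger effect on one core can be read from the two steps: the same change on two cores in this assay, an at least 1100-fold lower number (3.04 log units; beyond the scatter) from compound 1 to compound 2 and an at least 3.0-fold lower number (0.48 log units; beyond the scatter) from compound 3 to compound 4; the limit leaves it open whether they differ Compound 3 and compound 1 each give a limit of the assay rather than a number, so the true size of both steps remains unknown, and the series offers only two starting points without a measured value: the limit of > 100000 nM in this assay, at which 2 of the 4 values shown sit.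

On these data alone, whether the effect belongs to methyl specifically stays open, as an ethyl group, a chlorine atom or an amine in the same place would be needed to tell. How much of the difference between the two cores comes from the fused ring system and how much from the bromine also remains unresolved, with no single-change pair shown for either.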